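The compounds below may be only part of what the source reports. "The series", "measured", "known", "first", "only" and "open" are said of these compounds alone.

Compound 1 `CC(C)CN(C1CCc2ccc(F)cc21)S(=O)(=O)c1ccc2c(c1)C(=O)CC(C1CCOCC1)O2` was measured in a physicochemical assay for lipophilicity, at pH 7.4 (on this read-out higher numbers stand for higher lipophilicity and lower numbers for lower lipophilicity), and gave 4.03. Among the three compounds with numbers, compound 1 holds the second-highest place. Compound 2 `CCc1ccc2c(c1)CC(C)CN2S(=O)(=O)c1ccc2c(c1)C(=O)CC(C1CCOCC1)O2` gives 3.77 in this assay, a number within the usual scatter of the value of compound 1, so the two cannot be told apart. Compound 3 `CCc1ccc(N(CC(C)C)S(=O)(=O)c2ccc3cc(OCC4CCOCC4)c(C(=O)OC)cc3c2)cc1` gives 6.09 in this assay, a value beyond the scatter and the furthest from compound 1. Compound 4 `CCc1ccc(N(CC(C)C)S(=O)(=O)c2ccc3c(c2)C(=O)CC(C2CCOCC2)O3)cc1` has not yet been measured; it differs from compound 1 in one place: 4-ethylphenyl in place of 6-fluoro-2,3-dihydro-1H-inden-1-yl on a sulfonamide nitrogen. Within the data shown here, no measured pair shows this exact change on the shared core. The expected step in this assay is small, a number 0.13 log units lower from compound 1 to compound 4 (within the scatter), staying within the scatter. Compound 4 is therefore estimated at 3.9, with a range from 3.4 to 4.4.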

Compound 4, distribution coefficient: 4.21
Compound 4: middle estimate off by 0.31 log units, on the low side; low and high end bracket the measured number.
By their numbers in this assay, from the lowest: compounds 2, 1 and 4 (each within the scatter of the next, the first and the last beyond it); then compound 3.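

At this position, on a sulfonamide nitrogen, this assay gives a number 0.18 log units higher from compound 1 to compound 4 (within the scatter), so 4-ethylphenyl and 6-fluoro-2,3-dihydro-1H-inden-1-yl cannot be told apart on this read-out. This first direct step shows that losing the five-membered ring and the fluorine leaves no difference that can be resolved. Nothing measured here offers an explanation for the step. Going by these compounds, it remains open whether an amine or a carboxylic acid at this position would move the number beyond the scatter.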